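A few compounds are considered here, and "the series" means these few. Any claim that something is new, unique, unknown or untested is made for them only; others in the source may bear on it.

Working notes on the series: in a functional assay on MT4 cells (Homo sapiens) for antiproliferative activity (on this read-out higher numbers stand for lower toxicity in this test and lower numbers for higher toxicity in this test), compound 1 `Cc1cn(C2OC(CO[Si](C)(C)C(C)(C)C)C3(OS(=O)(=O)C=C3N)C2O[Si](C)(C)C(C)(C)C)c(=O)n(CCCNC(=O)[C@@H]2CCCN2C(=O)[C@H](C)N)c1=O` gives 20000 nM, the lowest of the three numbers so far. Compound 2 `Cc1cn(C2OC(CO[Si](C)(C)C(C)(C)C)C3(OS(=O)(=O)C=C3N)C2O[Si](C)(C)C(C)(C)C)c(=O)n(CCCNC(=O)[C@@H]2CCCN2C(=O)[C@@H](N)CCCCN)c1=O` gives 87000 nM, and compound 3 `Cc1cn(C2OC(CO[Si](C)(C)C(C)(C)C)C3(OS(=O)(=O)C=C3N)C2O[Si](C)(C)C(C)(C)C)c(=O)n(CCCNC(=O)[C@@H]2CCCN2C(=O)[C@@H](N)CCC(=O)O)c1=O` gives 64000 nM. Compound 4 `Cc1cn(C2OC(CO[Si](C)(C)C(C)(C)C)C3(OS(=O)(=O)C=C3N)C2O[Si](C)(C)C(C)(C)C)c(=O)n(CCCNC(=O)[C@H]2CCCN2C(=O)[C@@H](N)C(C)C)c1=O` remains unmeasured and places 1-((1-amino-2-methylpropyl)carbonyl)pyrrolidin-2-yl on a carbonyl carbon: 1-((1-amino-2-methylpropyl)carbonyl)pyrrolidin-2-yl in place of 1-((1-aminoethyl)carbonyl)pyrrolidin-2-yl on a carbonyl carbon. Two measured steps from compound 1 bear on this change, a 4.4-fold higher number from compound 1 to compound 2 (0.64 log units; beyond the scatter) and a 3.2-fold higher number from compound 1 to compound 3 (0.51 log units; beyond the scatter). Both are modest, and a 1.4-fold lower number from compound 2 to compound 3 (0.13 log units; within the scatter) stays within the scatter. For the measured compounds named here, no measured compound carries this exact group, so a similar or smaller rise is expected in this assay. The estimated step is a 2.3-fold higher number from compound 1 to compound 4 (0.35 log units; beyond the scatter). Compound 4 is estimated at 45000 nM, with an expected range of 20000 nM to 100000 nM.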

Compound 4, half-maximal cytotoxic concentration: 22000 nM
Compound 4: middle estimate off by 2.0-fold (0.31 log units), on the high side; the range from low to high includes it.
By their numbers in this assay, from the lowest: compounds 1 and 4 (each within the scatter of the next); then compounds 3 and 2 (each within the scatter of the next).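

The change to 1-((1-amino-2-methylpropyl)carbonyl)pyrrolidin-2-yl on this carbonyl carbon gives a 1.1-fold higher number from compound 1 to compound 4 (0.04 log units; within the scatter) in this assay, so a larger group here does not by itself raise the number. The rises seen with compounds 2 and 3 are therefore not shared by this group, which adds only carbon atoms to the one it replaces. Nothing on hand gives a reason for this difference. Still open, from the compounds shown here alone, is how an unbranched butyl chain or a benzyl group would read at this place. Going by these compounds, a hydroxymethyl group, carrying oxygen without an amine or a carboxylic acid, is equally open.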